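A few compounds are considered here, and "the series" means these few. Any claim that something is new, unique, unknown or untested is made for them only; others in the source may bear on it.

Among the measured compounds shown here, in a functional assay on A549 cells (Homo sapiens) for antiproliferative activity, read by MTT assay, with a stated time of 48 h (on this read-out higher numbers stand for weaker inhibition and lower numbers for stronger inhibition), compound 1 `COc1ccc(C(=O)c2ccc3c(c2)C=CC(C)(C)O3)c(NC(=O)CO)c1` gives 90 nM, the lowest of the two numbers so far, while compound 2 `COc1ccc(C(=O)c2ccc(OC)c3c2C=CC(C)(C)O3)c(NC(=O)CN)c1` gives 420 nM, a higher number beyond the scatter. Compound 3 `CCNCC(=O)Nc1cc(OC)ccc1C(=O)c1ccc2c(c1)C=CC(C)(C)O2` differs from compound 1 in one place: ethylamino in place of hydroxy on a saturated chain carbon bound to a carbonyl carbon, with ethylamino in place of hydroxy on a saturated chain carbon bound to a carbonyl carbon. For the measured compounds named here, no measured pair shows this change alone, so only a loose expectation is possible: a moderate move to a higher number, beyond the scatter. The estimated step is a 3.0-fold higher number from compound 1 to compound 3 (0.48 log units; beyond the scatter). For compound 3 the expected value is 270 nM, within an estimated range of 70 nM to 1000 nM.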

Compound 3, half-maximal inhibitory concentration: 1300 nM
Compound 3: the middle estimate sits 4.8-fold (0.68 log units) below what was measured; the measured number lies above the stated range.
By their numbers in this assay, from the lowest: compound 1; then compound 2; then compound 3.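

In this assay, putting ethylamino in place of hydroxy on a saturated chain carbon bound to a carbonyl carbon gives a 14-fold higher number from compound 1 to compound 3 (1.16 log units; beyond the scatter) as a large step. Among the compounds shown here, this is the only comparison here that changes one place alone, and it shows that the low number of compound 1 does not come from the shared core alone, since this group matters too. No measurement shown here explains the step.

As far as these compounds go, it remains open whether the loss follows the nitrogen or the ethyl part, which a plain amino group on the core of compound 1 would help separate. From the compounds shown here alone, how a carboxylic acid would fare at this place is also open.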